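Exchange of the anilino aryl group at the assay limit

The compounds below may be only part of what the source reports. "The series", "measured", "known", "first", "only" and "open" are said of these compounds alone.

In a functional assay on HT29-AK cells (Homo sapiens) for cytotoxicity, read by MTT assay, with a stated time of 48 h (a lower number here means a stronger inhibitor, a higher number a weaker inhibitor), compound 1 `Fc1cccc(-c2nc(Nc3ccccc3)c3ccccc3n2)c1` gives only a limit, > 50000 nM. Compound 2 `COc1ccccc1Nc1nc(-c2cccc(F)c2)nc2ccc(F)cc12` likewise gives only a limit in this assay, > 50000 nM. Compound 3 `Fc1cccc(-c2nc(Nc3ccccc3F)c3cc(F)ccc3n2)c1` also gives only a limit in this assay, > 50000 nM. The step from methoxy to fluoro, a step that the two limits leave unreadable from compound 2 to compound 3, is therefore not readable in size or direction. All three values rest on (the limit of > 50000 nM in this assay, at which 3 of the 3 values shown sit), so compound 3 stands where every measured member of the series stands, at the limit, with no number to set it apart from the others.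

Compound 4 `Fc1cccc(-c2nc(Nc3cccc(Br)c3)c3cc(F)ccc3n2)c1` differs from compound 3 by 3-bromophenyl in place of 2-fluorophenyl on a nitrogen on an aromatic ring. Among the measured compounds shown here, no measured step bears on this exchange. For the measured compounds named here, the only step, a step that the two limits leave unreadable from compound 2 to compound 3, concerns a different position and is itself unreadable. The value of compound 1 is a limit as well. Nothing in this assay can therefore be read as a direction for the exchange, and no step beyond the scatter is expected; the most probable outcome is a fourth limit. Compound 4 is estimated at 60000 nM, with a range from 15000 nM to 200000 nM. The expected step is a step that the limit leaves unreadable from compound 3 to compound 4, meaning no movement that the assay could resolve.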

Compound 4, half-maximal inhibitory concentration: > 50000 nM
Compound 4: a limit, no number (the forecaster's own chance of this, stated with the estimate: 80%); the middle value lies beyond the limit too.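

Compound 4 gives only a limit in this assay, > 50000 nM. The steps from compound 2 and from compound 3 to compound 4 cannot be read, and the series still holds no number: the limit of > 50000 nM in this assay, at which 4 of the 4 values shown sit.

The compounds shown leave open whether any exchange on the nitrogen or elsewhere on the shared core gives a measurable value in this assay.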